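Methyl for Benzyl on a Second Core

The source may report more compounds than this note shows. Statements on the series, on what has been measured and on what is new or still open speak of the compounds shown alone.

Compound 1 `C[Se]/C(=N\C(=O)c1cccs1)NC(=O)c1cccs1`, compound 2 `O=C(/N=C(/NC(=O)c1ccno1)[Se]Cc1ccccc1)c1ccno1` and compound 3 `O=C(/N=C(/NC(=O)c1cccs1)[Se]Cc1ccccc1)c1cccs1` were all tested in a functional assay on PC-3 cells (Homo sapiens) for cytotoxicity, read by MTT assay, with a stated time of 72 h; on this read-out lower numbers stand for stronger inhibition of growth and higher numbers for weaker inhibition of growth. In this assay compound 1 gives 1340 nM, compound 3 gives 49900 nM, and compound 2 gives 53100 nM. Compound 4 `C[Se]/C(=N\C(=O)c1ccno1)NC(=O)c1ccno1` has not yet been measured in this assay.

Compound 3 and compound 1 share one core and differ in one place: hydrogen in place of phenyl on a saturated chain carbon bound to a selenium atom. This change gives a 37-fold lower number from compound 3 to compound 1 (1.57 log units; beyond the scatter). The difference between the core of compound 2 and the core of compound 3 is not broken down here; their two values lie within the usual scatter of each other. The same change, applied to compound 2, yields compound 4: hydrogen in place of phenyl on a saturated chain carbon bound to a selenium atom.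

For compound 4 the expected step is a 30-fold lower number from compound 2 to compound 4 (1.47 log units; beyond the scatter). From the compounds shown here alone, this expectation rests on the earlier step from compound 3 to compound 1, a 37-fold lower number from compound 3 to compound 1 (1.57 log units; beyond the scatter), with a wide range since the core of compound 2 is untested in this respect. In this assay compound 4 is expected to give about 1800 nM, estimated between 500 nM and 8000 nM.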

Compound 4, concentration for 50% growth inhibition: 90 nM
Estimate against measurement, compound 4: 20-fold (1.30 log units) above; the whole stated range lies above it.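

Hydrogen in place of phenyl on a saturated chain carbon bound to a selenium atom gives a 590-fold lower number from compound 2 to compound 4 (2.77 log units; beyond the scatter) in this assay. The direction of the change therefore carries over between the two cores shown, with the number falling on both, but its size does not: the same change on two cores in this assay, a 37-fold lower number (1.57 log units; beyond the scatter) from compound 3 to compound 1 and a 590-fold lower number (2.77 log units; beyond the scatter) from compound 2 to compound 4, 16-fold (1.20 log units) apart, beyond the scatter of two such steps. Within the data shown here, this shows that, in this series, the size of the step on one core cannot be taken as a measure of the step on the other, yet with only two cores it does not show which feature of the cores accounts for the gap, or how far the direction would hold on any further core.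

The compounds shown carry only benzyl and methyl at this place, so it remains open how an ethyl group, a longer chain or a chain ending in an amine would compare. From the compounds shown here alone, it also remains open whether such groups would show the same dependence on the core.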